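Methoxy Added to a Pendant Phenyl Ring

The source may hold more compounds than are shown below. What is called first, only, known or untested is meant among the compounds shown, and "the series" means these compounds.

Compound 1 `CCCCNc1nc(N)nc2cccc(OCc3ccccc3)c12` was tested in an ADME assay on HEK293 cells for agonist activity at Toll-like receptor 8 (Homo sapiens), read by a luciferase reporter, with a stated time of 6 h (a higher number here means that more compound is needed for the effect, a lower number that less compound is needed), where compound 1 gives 1.66 uM. Compound 2 `CCCCNc1nc(N)nc2cccc(OCc3ccccc3OC)c12` differs from compound 1 in one place: methoxy in place of hydrogen on an aromatic carbon. In this assay compound 2 reaches only a limit, > 25 uM. That change gave an at least 15-fold higher number from compound 1 to compound 2 (1.17 log units; beyond the scatter). Compound 3 `CCCCNc1nc(N)nc2cccc(C(=O)N[C@@H](C)c3ccccc3)c12` has a different core; how its core differs from that of compound 1 is not broken down here. In this assay compound 3 also reaches only a limit, > 25 uM. Compound 4 `CCCCNc1nc(N)nc2cccc(C(=O)N[C@@H](C)c3cccc(OC)c3)c12` is not yet measured and differs from compound 3 by methoxy in place of hydrogen on an aromatic carbon, the same kind of change as from compound 1 to compound 2, but here meta to a large group rather than ortho to a large group. The ceiling of this assay is the limit of > 25 uM in this assay, at which 2 of the 3 values shown sit. With compound 3 already at that ceiling, compound 4 is expected to stay there, an estimated step that the limit leaves unreadable from compound 3 to compound 4. The number for compound 4 is estimated at 30 uM, between 12 uM and 100 uM.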

Compound 4, minimum effective concentration: > 25 uM
Compound 4 was reported as a limit; the forecaster's own chance of this, stated with the estimate: 85%; the middle value lies beyond the limit too.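

Compound 3 and compound 4 both sit at a limit in this assay, so no step between them can be read: the limit of > 25 uM in this assay, at which 3 of the 4 values shown sit.

Whether the methoxy changes anything on this amide series stays open, since the compounds shown give no measured number there.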